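The compounds below may be only part of what the source reports. "The series", "measured", "known", "first", "only" and "open" are said of these compounds alone.

Compound 1 `CCCCSc1nc(N)nc2c1ncn2/C=C1/CC1(CO)CO`: in an ADME assay on Akata cells (Homo sapiens) for cytotoxicity, with a stated time of 7 days (on this read-out lower numbers stand for higher toxicity in this test and higher numbers for lower toxicity in this test), compound 1 reaches only the assay limit, > 20000 nM.
Compound 2 `CN(C)c1nc(N)nc2c1ncn2/C=C1/CC1(CO)CO`: in this assay compound 2 likewise stops at a limit, > 24000 nM.
Compound 3 `CCCCCCOc1nc(N)nc2c1ncn2/C=C1/CC1(CO)CO`: in this assay compound 3 again gives a limit, > 20000 nM.

All three values in this assay are limits, so none of the pairwise steps can be read: a step that the two limits leave unreadable from compound 1 to compound 2, a step that the two limits leave unreadable from compound 1 to compound 3, a step that the two limits leave unreadable from compound 2 to compound 3. Compound 3 thus stands level with the other two as far as the data allow; two of the three values sit at the limit of > 20000 nM in this assay, at which 2 of the 3 values shown sit, and one at the limit of > 24000 nM in this assay, at which 1 of the 3 values shown sits, and no ordering among them is possible.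

Compound 4 `CNc1nc(N)nc2c1ncn2/C=C1/CC1(CO)CO` differs from compound 3 by methylamino in place of hexyloxy on an aromatic carbon. Going by the values given here, the steps that bear on this change are the three unreadable ones above: every replacement on the same aromatic carbon, whether butylsulfanyl, dimethylamino or hexyloxy, left the read-out at a limit. The change to methylamino is most akin to the dimethylamino of compound 2, whose value > 24000 nM is itself a limit. The expectation for this assay is therefore no step beyond the scatter, a step that the limit leaves unreadable from compound 3 to compound 4, with a limit the most probable outcome. Compound 4 is estimated at 25000 nM, with a range from 12000 nM to 60000 nM.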

Compound 4, half-maximal cytotoxic concentration: > 24000 nM
Compound 4 was reported as a limit (the forecaster's own chance of this, stated with the estimate: 85%); the middle value is on the limit's open side.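

In this assay compound 4 gives only a limit, > 24000 nM. Going by these compounds alone, compound 1, compound 2 and compound 3 also stop at limits, so no step to compound 4 can be read. The compounds shown leave open where the half-maximal cytotoxic concentration of any of the four lies, and whether the group on this aromatic carbon alters it at all.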